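This account rests on a few compounds, and the source may have more. Where it says the series, first, only, none or still open, it means among the compounds named here.

In an assay on isolated protein for inhibition of aldehyde dehydrogenase 1A1 (Homo sapiens), read by spectrophotometry, tested at 10 uM (on this read-out lower numbers stand for less inhibition and higher numbers for more inhibition at the one concentration tested (going by the name of the read-out)), compound 2 `Cc1cccc(Cn2c(CN3CCN(C(=O)C4CCCC4)CC3)nc3ccccc32)c1` stands highest of the three measured compounds, with 67.5%. Its nearest neighbour on that scale is compound 3 `Cc1ccccc1Cn1c(CN2CCN(C(=O)C3CC3)CC2)nc2ccccc21`, which gives 29.1% in this assay, and the furthest is compound 1 `CCn1c(CN2CCN(C(=O)C3CC3)CC2)nc2ccccc21`, which gives 20.8%. Among the compounds with values here, the only measured step that changes one place at a time is the one in which a 2-methylphenyl replaces methyl on a saturated chain carbon bound to an aromatic nitrogen, and that step, a number 8.3 percentage points higher from compound 1 to compound 3 (within the scatter), stays within the scatter.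

Compound 4 `Cc1cccc(Cn2c(CN3CCN(C(=O)c4ccco4)CC3)nc3ccccc32)c1` is not yet measured. It differs from compound 2 in one place: furan-2-yl in place of cyclopentyl on a carbonyl carbon. Within the data shown here, none of the measured compounds differs from another solely at this carbonyl carbon, so no measured step bears on this change; the gap between compound 1 and compound 2, and between compound 3 and compound 2, each arises from two changes at once. With nothing to anchor the replacement of cyclopentyl by furan-2-yl, a moderate drop from the high number of compound 2 is the expected outcome, though a result close to compound 2 cannot be excluded. The expected step is a number 17.5 percentage points lower from compound 2 to compound 4 (beyond the scatter). Compound 4 is therefore estimated at 50% in this assay, with a range from 20% to 75%.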

Compound 4, a percentage reported as inhibition, at one concentration (the size of the read-out at that concentration, not a potency): 73.2%
The estimate for compound 4 lay 23.2 percentage points below the measured number; the measured number falls inside the stated range.
By their numbers in this assay, from the lowest: compounds 1 and 3 (each within the scatter of the next); then compounds 2 and 4 (each within the scatter of the next).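

At the carbonyl carbon, this assay now has its first step that changes this place alone: furan-2-yl in place of cyclopentyl gives a number 5.7 percentage points higher from compound 2 to compound 4 (within the scatter) and stays within the scatter. An aromatic ring with one oxygen and one hydrogen-bond acceptor can therefore stand in place of a non-aromatic ring of carbon only, with the same count of heavy atoms, without the two compounds being told apart on this read-out, and the high numbers at this position are no longer tied to cyclopentyl alone, though this rests on a single pair that shares the rest of its structure. Nothing available accounts for how closely the two groups agree.

The compounds shown leave open whether a phenyl ring, a thiophen-2-yl ring or a straight butyl chain on the same carbonyl carbon would also keep the number in this range. They also leave open whether the furan-2-yl replacement would give a similar step on the shared core with a different group on its aromatic nitrogen.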